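Aryl swap on a piperazine: expected adenosine A3 inhibition

A few compounds are considered here, and "the series" means these few. Any claim that something is new, unique, unknown or untested is made for them only; others in the source may bear on it.

Measured compounds:
- Compound 1, `Nc1scc(CN2CCN(c3ccc(Cl)cc3Cl)CC2)c1C(=O)c1ccc(Cl)cc1`: 0%
- Compound 2, `Nc1scc(CN2CCN(c3c(F)cc(F)cc3F)CC2)c1C(=O)c1ccc(Cl)cc1`: 0%

In an assay on CHO cells for displacement of a labelled ligand from adenosine receptor A3 (Homo sapiens), read by scintillation counting, with a stated time of 120 min, tested at 10 uM (on this read-out lower numbers stand for less inhibition and higher numbers for more inhibition at the one concentration tested (going by the name of the read-out)), compound 2 gives 0%, level with compound 1, which gives 0%. For the measured compounds named here, the only measured step, no change at the digits printed from compound 1 to compound 2 (within the scatter), changed nothing beyond the scatter. Compound 3, `Nc1scc(CN2CCN(c3ccc(Cl)c(Cl)c3)CC2)c1C(=O)c1ccc(Cl)cc1`, differs from compound 2 by 3,4-dichlorophenyl in place of 2,4,6-trifluorophenyl on an amine nitrogen in a ring. Since the earlier change of the aromatic group on this ring nitrogen, from compound 1 to compound 2, left the read-out unchanged, no step beyond the scatter is expected here either, so no change at the digits printed from compound 2 to compound 3 (within the scatter) is expected to be flat. Compound 3 is therefore estimated at 0%, within -10% to 15%.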

Compound 3, a percentage reported as inhibition, at one concentration (the size of the read-out at that concentration, not a potency): 3%
The estimate for compound 3 lay 3 percentage points below the measured number, within the range that was stated.
By their numbers in this assay, from the lowest: compounds 1, 2 and 3 (each within the scatter of the next).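

With a number 3 percentage points higher from compound 2 to compound 3 (within the scatter) and a number 3 percentage points higher from compound 1 to compound 3 (within the scatter) in this assay as the steps to 3,4-dichlorophenyl, three halogen-bearing phenyl groups on this ring nitrogen now read alike. They include two dichlorophenyl groups that differ only in where their chlorines sit, a comparison the earlier pair could not offer. Nothing measured here explains this flat read-out. As far as these compounds go, whether a group of another kind on this nitrogen, such as a methoxyphenyl, a benzyl or a simple alkyl chain, would give a different read-out stays open. So does whether any change elsewhere on the shared core would.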